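Piperidine for methylpiperazine on the anilino ring

The compounds below may be only part of what the source reports. "The series", "measured", "known", "first", "only" and "open" are said of these compounds alone.

The series rests on one core, that of compound 1 `CN1CCN(c2ccc(Nc3ncc4c(n3)N(C3CCCC3)CC(=O)N4)cc2)CC1`. In a functional assay on HT-29 cells (Homo sapiens) for inhibition, read by MTT assay, with a stated time of 48 h (a higher number here means a weaker inhibitor, a lower number a stronger inhibitor), compound 1 gives 5220 nM. Compound 2 `O=C1CN(C2CCCC2)c2nc(Nc3ccc(N4CCCCC4)cc3)ncc2N1` carries the change (piperidin-1-yl in place of 4-methylpiperazin-1-yl on an aromatic carbon); in this assay compound 2 gives 5540 nM, and the step is a 1.1-fold higher number from compound 1 to compound 2 (0.03 log units; within the scatter). Compound 3 `CCN1C(=O)CN(C2CCCC2)c2nc(Nc3ccc(N4CCN(C)CC4)cc3)ncc21` differs from compound 1 by ethyl in place of hydrogen on an amide-type nitrogen in a ring; in this assay compound 3 gives 10300 nM, a step of a 2.0-fold higher number from compound 1 to compound 3 (0.30 log units; within the scatter). Compound 3 has the highest of the three measured numbers, but its gaps to compound 2 and to compound 1 both lie within the scatter, so no order is read from them.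

Compound 4 `CCN1C(=O)CN(C2CCCC2)c2nc(Nc3ccc(N4CCCCC4)cc3)ncc21` has not yet been measured in this assay. It differs from compound 3 by piperidin-1-yl in place of 4-methylpiperazin-1-yl on an aromatic carbon, which is the same change as that from compound 1 to compound 2: the place, on an aromatic carbon of a six-membered aromatic ring of carbon only, para to a large group, is described in the same words for both pairs. The cores of the two pairs differ as given by ethyl in place of hydrogen on an amide-type nitrogen in a ring. Among the measured compounds shown here, the one measured instance of the change, a 1.1-fold higher number from compound 1 to compound 2 (0.03 log units; within the scatter), left the number essentially unchanged. For compound 4 the step expected in this assay is a 1.1-fold higher number from compound 3 to compound 4 (0.03 log units; within the scatter), a step of similar size, which rests on a 1.1-fold higher number from compound 1 to compound 2 (0.03 log units; within the scatter). Compound 4 is therefore estimated at 11000 nM in this assay, with an expected range from 5000 nM to 25000 nM.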

Compound 4, half-maximal inhibitory concentration: > 30000 nM
Compound 4 ended at the assay's limit; the forecaster's own chance of this, stated with the estimate: 10%; middle value at least 2.7-fold (0.43 log units) away from the limit.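

In this assay compound 4 gives > 30000 nM, which is a limit of the assay and not a number. With ethyl on the amide-type nitrogen, the step for piperidin-1-yl in place of 4-methylpiperazin-1-yl is an at least 2.9-fold higher number from compound 3 to compound 4 (0.46 log units; beyond the scatter), so within these two pairs the change does not carry unchanged from the core of compound 1 to the core of compound 3: the same change on two cores in this assay, a 1.1-fold higher number (0.03 log units; within the scatter) from compound 1 to compound 2 and an at least 2.9-fold higher number (0.46 log units; beyond the scatter) from compound 3 to compound 4, at least 2.7-fold (0.43 log units) apart, beyond the scatter of two such steps The ethyl change likewise depends on its partner group, giving an at least 5.4-fold higher number from compound 2 to compound 4 (0.73 log units; beyond the scatter), so the two changes do not act independently in these four compounds, although this rests on one pair for each core, sets no general rule for the series and leaves the exact size of the gap undetermined: the same change on two cores in this assay, a 2.0-fold higher number (0.30 log units; within the scatter) from compound 1 to compound 3 and an at least 5.4-fold higher number (0.73 log units; beyond the scatter) from compound 2 to compound 4, at least 2.7-fold (0.43 log units) apart, beyond the scatter of two such steps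

The compounds shown leave open whether the same dependence holds with methyl or a longer chain on the amide-type nitrogen, or with morpholin-4-yl or a primary amine in place of piperidin-1-yl on the aromatic carbon. They also leave open what lies behind the dependence, since nothing shown here separates one possible cause from another.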